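Carbamate ester change on the pyrimidine-fused core

The source may hold more compounds than are shown below. What is called first, only, known or untested is meant among the compounds shown, and "the series" means these compounds.

Three compounds of the series have a number in a functional assay on CHO-K1 cells for agonist activity at Glucose-dependent insulinotropic receptor (Homo sapiens), read by a luciferase reporter, with a stated time of 5 h; on this read-out lower numbers stand for an effect already at smaller amounts and higher numbers for an effect only at larger amounts of compound. Compound 1 `CC(C)OC(=O)N1CCC(Oc2cccc3c2CCN3c2ccc(S(C)(=O)=O)cc2)CC1` gives 501 nM in this assay. Compound 2 `CC(C)(C)OC(=O)N1CCC(Oc2cccc3c2ccn3-c2ccc(S(C)(=O)=O)cc2)CC1` gives 631 nM. Compound 3 `CC(C)(C)OC(=O)N1CCC(Oc2ncnc3c2CCN3c2ccc(S(C)(=O)=O)cc2F)CC1` gives 20 nM, the lowest of the three numbers; compound 1 stands a long way higher and compound 2 further still, both gaps beyond the scatter. Compounds 1 and 2 differ from compound 3 in several places at once, so none of these gaps can be tied to a single change.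

Compound 4 `CCCOC(=O)N1CCC(Oc2ncnc3c2CCN3c2ccc(S(C)(=O)=O)cc2F)CC1` keeps the core, the fluorine on the aryl ring and the methylsulfonyl group of compound 3 and differs only in the carbamate: propyl in place of tert-butyl on an oxygen next to a carbonyl group. For the measured compounds named here, no step between measured compounds isolates a change of this kind, so the expectation rests on compound 3 alone. The step is expected to be small, at most a modest move toward higher numbers in this assay, and may well sit within the scatter a 1.6-fold higher number from compound 3 to compound 4 (0.20 log units; within the scatter). For compound 4 the estimate in this assay is 32 nM, with a range from 10 nM to 100 nM.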

Compound 4, half-maximal effective concentration: 79.4 nM
Beside the measured number, compound 4's estimate is 2.5-fold (0.39 log units) below it; the measured number falls inside the stated range.
By their numbers in this assay, from the lowest: compound 3; then compound 4; then compounds 1 and 2 (each within the scatter of the next).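

Within the carbamate, the ester group is the first place in the series where a single change can be read: in this assay propyl in place of tert-butyl on an oxygen next to a carbonyl group gives a 4.0-fold higher number from compound 3 to compound 4 (0.60 log units; beyond the scatter) and this step lies beyond the scatter. The number at this position therefore responds to the group on the oxygen while the core, the fluorine and the methylsulfonyl group stay fixed, and the tert-butyl ester holds the lower number of the pair. Nothing measured here gives a reason for the step.

Going by these compounds, with only these two esters on this core, it remains open how the number moves with other groups at this position. A cyclopropyl group or a longer chain such as pentyl on the same oxygen would test that.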